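The compounds below may be only part of what the source reports. "The series", "measured", "known", "first", "only" and "open" are said of these compounds alone.

In a functional assay on U-87MG ATCC cells for inhibition, with U-87 MG (Homo sapiens) as the target, read by MTT assay, with a stated time of 48 h (a higher number here means a weaker inhibitor, a lower number a stronger inhibitor), three compounds built on a shared core have been measured. Compound 1 `CS(=O)(=O)c1ccc(-c2nc3ccccn3c2Sc2ccccc2)cc1` gives 77200 nM. Compound 2 `COc1ccc(-c2nc3ccccn3c2Sc2ccccc2)cc1` reports only a limit, > 100000 nM, and not a number. Compound 3 `CSc1ccc(-c2nc3ccccn3c2Sc2ccccc2)cc1` gives 26900 nM, the lower of the two actual numbers, which makes it the strongest inhibitor of the three.

Compound 4 `c1ccc(Sc2c(-c3ccsc3)nc3ccccn23)cc1` has not yet been measured. It differs from compound 3 in one place, with thiophen-3-yl in place of 4-(methylsulfanyl)phenyl on an aromatic carbon.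

The measured steps exchange only methylsulfonyl, methoxy and methylsulfanyl. They show a 2.9-fold lower number from compound 1 to compound 3 (0.46 log units; beyond the scatter), then an at least 3.7-fold lower number from compound 2 to compound 3 (0.57 log units; beyond the scatter), and finally an at least 1.2-fold higher number from compound 1 to compound 2 (0.11 log units; that floor lies within the scatter). Both steps that end at compound 3 are modest or at least modest, and both favour the methylsulfanyl group. Compound 4 gives up that group along with the six-membered ring that carries it. Among the measured compounds shown here, no measured step replaces that ring, so this evidence is indirect.

A modest move towards weaker inhibition therefore seems the likeliest outcome, about the size of the steps to compound 3. The expected step is a 2.2-fold higher number from compound 3 to compound 4 (0.35 log units; beyond the scatter). For compound 4, the estimated value is 60000 nM, with an expected range from 20000 nM to 100000 nM.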

Compound 4, half-maximal inhibitory concentration: 58600 nM
Compound 4: the middle estimate sits 1.0-fold (0.01 log units) above what was measured; low and high end bracket the measured number.
By their numbers in this assay, from the lowest: compound 3; then compounds 4 and 1 (each within the scatter of the next). At a limit, above all of these: compound 2.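

In this assay, among the compounds shown here, this is the first change to the ring itself at this position rather than to the group it carries, and swapping 4-(methylsulfanyl)phenyl for the smaller thiophen-3-yl gives a 2.2-fold higher number from compound 3 to compound 4 (0.34 log units; beyond the scatter). So a five-membered aromatic ring with no further group can stand here and still give a real number, although the methylsulfanyl compound, compound 3, keeps the lower one. Compound 2 carries a limit and not a number, so its comparison with the thiophene reads only as an at least 1.7-fold lower number from compound 2 to compound 4 (0.23 log units; that floor lies within the scatter), which does not firmly order the two: the limit of > 100000 nM in this assay, at which 1 of the 4 values shown sits.

The step from compound 3 to compound 4 changes the ring and removes the methylsulfanyl group in one move, so its size cannot be divided between the two, and a phenyl group with no substituent at this position would be needed to separate them. As far as these compounds go, it also remains open how an amine or a carboxylic acid on the ring here would read, or whether any change to the phenylsulfanyl group on the neighbouring ring atom would move the number further.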